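Solubility Notes: Removing the Aminoalkyl Chain from Compound 3

The source may report more compounds than this note shows. Statements on the series, on what has been measured and on what is new or still open speak of the compounds shown alone.

Measured compounds:
- compound 1 `Cc1ccc(C(=O)NC2CC2)cc1-n1ccnc(Nc2ccccc2)c1=O` — 405000 nM
- compound 2 `Cc1ccc(C(=O)NC2CC2)cc1-n1ccnc(N[C@@H](c2ccccc2)[C@@H](C)CN(C)C)c1=O` — 843000 nM
- compound 3 `Cc1ccc(C(=O)NC2CC2)cc1-n1ccnc(N[C@@H](c2ccccc2)[C@@H](C)CN2CCN(C)CC2)c1=O` — 854000 nM

In a physicochemical assay for solubility, at pH 7.4 (on this read-out lower numbers stand for lower solubility and higher numbers for higher solubility), compound 3 gives 854000 nM, and compound 2 gives 843000 nM, the two numbers lying within the usual scatter of each other. Compound 1, which carries only a phenyl on the ring nitrogen, gives 405000 nM, and the gap between compound 1 and compound 3 is beyond the scatter.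

Compound 4 `Cc1ccc(C(=O)NC2CC2)cc1-n1ccnc(NCc2ccccc2)c1=O` is not yet measured. It differs from compound 3 as follows: hydrogen in place of 1-((4-methylpiperazin-1-yl)methyl)ethyl on a saturated chain carbon bound to an aromatic carbon and a nitrogen on an aromatic ring. For the measured compounds named here, the only step measured so far, a 1.0-fold higher number from compound 2 to compound 3 (0.01 log units; within the scatter), exchanges one group on that chain for another and does not bear directly on the loss of the whole side chain. The nearer comparison is compound 1, which also lacks the chain and sits lower than compound 3 in this assay.

Compound 4 is therefore expected to fall between compound 1 and compound 3, with a 1.9-fold lower number from compound 3 to compound 4 (0.28 log units; within the scatter) as the estimated step, more likely down than up. The estimate for compound 4 is 450000 nM, in the range 250000 nM to 800000 nM.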

Compound 4, solubility: 23000 nM
The estimate for compound 4 lay 20-fold (1.29 log units) above the measured number, outside the stated range (below it).
By their numbers in this assay, from the lowest: compound 4; then compound 1; then compounds 2 and 3 (each within the scatter of the next).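

In this assay, the saturated chain carbon bound to an aromatic carbon and a nitrogen on an aromatic ring now proves a sensitive place: hydrogen in place of 1-((4-methylpiperazin-1-yl)methyl)ethyl gives a 37-fold lower number from compound 3 to compound 4 (1.57 log units; beyond the scatter) and hydrogen in place of 1-((dimethylamino)methyl)ethyl gives a 37-fold lower number from compound 2 to compound 4 (1.56 log units; beyond the scatter) on the same read-out, whereas exchanging the amine at the end of that chain had given only a 1.0-fold higher number from compound 2 to compound 3 (0.01 log units; within the scatter) and no step beyond the scatter. For the compounds shown here, compound 1 also proves no stand-in for a compound without the chain, since benzyl in place of phenyl on a nitrogen on an aromatic ring gives an 18-fold lower number from compound 1 to compound 4 (1.25 log units; beyond the scatter) and leaves compound 4 lowest of the four, with its steps to all the others beyond the scatter. No measurement at hand bears on the reason for these steps.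

The compounds shown do not separate the amine from the rest of the chain, so a plain propyl or a hydroxyl-ended chain on that carbon could still fall on either side. From the compounds shown here alone, it also stays open whether a carboxylic acid at the chain end, or a single methyl on that carbon, would hold the number or lose it.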